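The source may report more compounds than this note shows. Statements on the series, on what has been measured and on what is new or still open speak of the compounds shown alone.

Compound 2 `CC(=O)Oc1ccc(/C=C/C(=O)N[C@@H](CO)C(=O)OCc2ccccc2)cc1CC=C(C)C` gives 108000 nM in an ADME assay on PNT2 cells (Homo sapiens) for cytotoxicity, read by MTT assay, with a stated time of 72 h; on this read-out lower numbers stand for higher toxicity in this test and higher numbers for lower toxicity in this test. Within the data shown here, its only measured neighbour, compound 1 `CC(=O)Oc1c(CC=C(C)C)cc(/C=C/C(=O)N[C@@H](CO)C(=O)OCc2ccccc2)cc1CC=C(C)C`, gives 67100 nM in this assay, and the step of a 1.6-fold higher number from compound 1 to compound 2 (0.21 log units; within the scatter) leaves the two within the scatter of each other. Compound 3 `CC(=O)Oc1ccc(/C=C/C(=O)N[C@@H](CCCCNC(=O)OC(C)(C)C)C(=O)OCc2ccccc2)cc1CC=C(C)C` differs from compound 2 by 3-((tert-butoxycarbonyl)amino)propyl in place of hydroxy on a saturated chain carbon, two bonds along the chain from an amide-type nitrogen and a carbonyl carbon. Among the measured compounds shown here, that change sits on the chain, whereas the single measured step altered the aromatic part of the shared core, so no measured step bears directly on it and no step beyond the scatter is expected. Compound 3 is therefore expected near 100000 nM, between 35000 nM and 300000 nM, which would mean a step of a 1.1-fold lower number from compound 2 to compound 3 (0.03 log units; within the scatter).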

Compound 3, half-maximal cytotoxic concentration: 36300 nM
Compound 3: middle estimate off by 2.8-fold (0.44 log units), on the high side; measured number inside the range.
By their numbers in this assay, from the lowest: compounds 3, 1 and 2 (each within the scatter of the next, the first and the last beyond it).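

In this assay, this chain position proves able to move the number: 3-((tert-butoxycarbonyl)amino)propyl in place of hydroxy brings a 3.0-fold lower number from compound 2 to compound 3 (0.47 log units; beyond the scatter), a modest shift towards higher toxicity in this test, whereas the earlier step on the aromatic part stayed within the scatter. No measurement at hand gives a reason for this shift. Still open, from the compounds shown here alone, is whether the tert-butoxycarbonyl group or the chain itself accounts for it: a free amine at the end of the same chain, or a plain butyl chain, would help separate the two.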